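From thiophen-2-yl to thiophen-3-yl in compound 4

The compounds below may be only part of what the source reports. "The series", "measured", "known", "first", "only" and "open" are said of these compounds alone.

Compound 1 `OC[C@H]1O[C@@H](n2cc(F)c3c(-c4ccsc4)ncnc32)[C@H](O)[C@@H]1O`: 66 nM
Compound 2 `OC[C@H]1O[C@@H](n2cc(Cl)c3c(-c4ccco4)ncnc32)[C@H](O)[C@@H]1O`: > 10000 nM, a limit
Compound 3 `OC[C@H]1O[C@@H](n2cc(Cl)c3c(-c4cccs4)ncnc32)[C@H](O)[C@@H]1O`: 13 nM

These compounds were tested in a functional assay on DU-145 cells (Homo sapiens), read by sulforhodamine B assay, with a stated time of 5 days; on this read-out higher numbers stand for weaker inhibition of growth and lower numbers for stronger inhibition of growth. Compound 3 gives 13 nM, the lowest of the two actual numbers, and the number for compound 1 stands higher, beyond the scatter. Compound 2 gives > 10000 nM, which is a limit and not a number.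

Compound 4 `OC[C@H]1O[C@@H](n2cc(Cl)c3c(-c4ccsc4)ncnc32)[C@H](O)[C@@H]1O` departs from compound 3 in a single group: thiophen-3-yl in place of thiophen-2-yl on an aromatic carbon. Among the measured compounds shown here, no measured step covers this exact change. The closest is an at least 760-fold lower number from compound 2 to compound 3 (2.88 log units; beyond the scatter), which puts thiophen-2-yl in place of furan-2-yl on the same aromatic carbon. That step shows that the group here can matter greatly in this assay, but it exchanges one ring for another, so it does not set the size of the present change. Compound 1, which also carries thiophen-3-yl, gives 66 nM, so this group can go with a low number. A modest rise is therefore expected, and no collapse to a limit. The estimated step is a 2.3-fold higher number from compound 3 to compound 4 (0.36 log units; beyond the scatter), toward weaker inhibition of growth. For compound 4 the estimate is 30 nM, with an expected range from 8 nM to 150 nM.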

Compound 4, concentration for 50% growth inhibition: 18 nM
Estimate against measurement, compound 4: 1.7-fold (0.22 log units) above; measured number inside the range.
By their numbers in this assay, from the lowest: compounds 3 and 4 (each within the scatter of the next); then compound 1. At a limit, above all of these: compound 2.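

In this assay, the step of a 1.4-fold higher number from compound 3 to compound 4 (0.14 log units; within the scatter) shows that, with chloro on the shared core, the thiophene ring can be joined to this aromatic carbon as thiophen-2-yl or as thiophen-3-yl with no difference that stands out from the scatter. The step of an at least 550-fold lower number from compound 2 to compound 4 (2.74 log units; beyond the scatter) shows that the thiophen-3-yl compound, like the thiophen-2-yl compound, stands far from the furan-2-yl compound, though this step starts from compound 2, whose value is a limit and not a number: the limit of > 10000 nM in this assay, at which 1 of the 4 values shown sits. With thiophen-3-yl held the same, the comparison gives a 3.7-fold lower number from compound 1 to compound 4 (0.56 log units; beyond the scatter), so chloro in place of fluoro on the other aromatic carbon changes the number by more than the scatter, which the thiophene exchange on its own does not.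

The compounds shown leave open whether furan-3-yl would stand with furan-2-yl or with the two thiophene compounds, and whether phenyl or an amine on this carbon would be tolerated. They also leave open whether chloro in place of fluoro would give a similar step with thiophen-2-yl, and how bromo would compare at that place.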